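The source may hold more compounds than are shown below. What is called first, only, known or untested is meant among the compounds shown, and "the series" means these compounds.

Compound 1 `Clc1cc(Cl)cc(CO[C@H]2CCCN(Cc3ccccn3)[C@H]2c2ccccc2)c1` is the reference point in an assay on isolated protein for activation of cGMP-dependent protein kinase 1 (Homo sapiens), read by ADP-Glo, with stated times of 120 min and 40 min; a higher number here means that more compound is needed for the effect, a lower number that less compound is needed. Compound 1 returns only the limit > 200000 nM, a bound of the assay rather than a number, standing at the limit of > 200000 nM in this assay, at which 1 of the 2 values shown sits. Compound 2 `COC(=O)Nn1c(C[C@H]2CCC[C@H](OCc3cc(C(F)(F)F)cc(C(F)(F)F)c3)[C@@H]2c2ccccc2)n[nH]c1=O`, on a different core, gives 4500 nM in this assay. Compound 3 `O=C(O)c1ccc(CN2CCC[C@H](OCc3cc(Cl)cc(Cl)c3)[C@@H]2c2ccccc2)cn1` is not yet measured; it differs from compound 1 by 6-carboxypyridin-3-yl in place of pyridin-2-yl on a saturated chain carbon bound to an amine nitrogen in a ring. Going by the values given here, no measured step covers this change, so any direction is open, and a result at the limit again would not surprise. Compound 3 is estimated at 100000 nM, with a range from 20000 nM to 300000 nM. The expected step is an at least 2.0-fold lower number from compound 1 to compound 3 (0.30 log units; that floor lies within the scatter), toward less compound needed, but weakly held.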

Compound 3, half-maximal effective concentration: > 200000 nM
Compound 3 was reported as a limit; the forecaster's own chance of this, stated with the estimate: 55%; middle value at least 2.0-fold (0.30 log units) away from the limit.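

Going by these compounds alone, compound 3 gives > 200000 nM in this assay, a limit of the assay and the same limit as compound 1, so no step between compound 1 and compound 3 can be read. Whether 6-carboxypyridin-3-yl in place of pyridin-2-yl shifts the number in either direction stays open: the limit of > 200000 nM in this assay, at which 2 of the 3 values shown sit.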